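Amino for isopropyl on the saturated ring carbon

The source may report more compounds than this note shows. Statements on the series, on what has been measured and on what is new or still open speak of the compounds shown alone.

Three analogues of the shared core have been measured in an assay on cells for inhibition of sodium/hydrogen exchanger (Oryctolagus cuniculus); a higher number here means a weaker inhibitor, a lower number a stronger inhibitor. Compound 1 `Cc1cc2c(cc1C(=O)N=C(N)N)S(=O)(=O)CCC2C` gives 45 nM. Compound 2 `Cc1cc2c(cc1C(=O)N=C(N)N)S(=O)(=O)CCCC2` gives 19 nM. Compound 3 `Cc1cc2c(cc1C(=O)N=C(N)N)S(=O)(=O)CC2C(C)C` gives 21 nM, the second highest of the three numbers, within the scatter of compound 2 and beyond the scatter relative to compound 1. Compound 4 `Cc1cc2c(cc1C(=O)N=C(N)N)S(=O)(=O)CC2N` has not been measured; it differs from compound 3 by amino in place of isopropyl on a saturated ring carbon. For the measured compounds named here, no step between measured compounds mirrors this change, so the expectation rests on the measured spread alone. The step from compound 3 to compound 4 is expected to be a 2.9-fold higher number from compound 3 to compound 4 (0.46 log units; beyond the scatter), a modest weakening somewhat beyond the scatter in this assay. On this basis compound 4 is estimated at 60 nM, with a range from 15 nM to 250 nM.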

Compound 4, half-maximal inhibitory concentration: 116 nM
The estimate for compound 4 lay 1.9-fold (0.29 log units) below the measured number; measured number inside the range.
By their numbers in this assay, from the lowest: compounds 2 and 3 (each within the scatter of the next); then compound 1; then compound 4.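

In this assay, amino in place of isopropyl on the saturated ring carbon gives a 5.5-fold higher number from compound 3 to compound 4 (0.74 log units; beyond the scatter), so the group at this carbon can shift the number beyond the scatter. The earlier compounds shown here could not show this, as no pair among them differs in one place. No measurement at hand accounts for the step.

Open, on these data alone, is whether the change in size or the hydrogen-bond donor and acceptor of amino matters here. A methyl, a hydroxyl or a dimethylamino group at this carbon could separate the two.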